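From compound 2 to compound 3: losing a hydroxymethyl

A few compounds are considered here, and "the series" means these few. Any claim that something is new, unique, unknown or untested is made for them only; others in the source may bear on it.

In an ADME assay on Vero cells (Chlorocebus sabaeus) for cytotoxicity, read by resazurin assay, with a stated time of 2 days (a higher number here means that more compound is tolerated, a lower number that less compound is tolerated), compound 1 (`CC(=O)OC[C@H]1O[C@@H](CC(=O)/C=C/c2ccc(NC(=O)Nc3ccccc3)cc2)[C@H](OC(C)=O)[C@@H](OC(C)=O)[C@@H]1OC(C)=O`) reads 820000 nM and compound 2 (`Cc1ccc(S(=O)(=O)Nc2cccc(/C=C/C(=O)C[C@@H]3O[C@H](CO)[C@@H](O)[C@H](O)[C@H]3O)c2)cc1`) reads 381000 nM as the lower of the two numbers, a gap beyond the usual scatter. Compound 3 (`Cc1ccc(S(=O)(=O)Nc2cccc(/C=C/C(=O)C[C@@H]3OC[C@@H](O)[C@H](O)[C@H]3O)c2)cc1`) carries hydrogen in place of hydroxymethyl on a saturated ring carbon, next to the ring oxygen (hydrogen in place of hydroxymethyl on a saturated ring carbon). Among the measured compounds shown here, no measured pair shows this change, so the expectation in this assay is loose, and no step beyond the scatter is foreseen. The estimated step of a 1.0-fold higher number from compound 2 to compound 3 (0.02 log units; within the scatter) is expected to stay within the scatter. Compound 3 is estimated at 400000 nM with 180000 nM to 900000 nM as its expected range.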

Compound 3, half-maximal cytotoxic concentration: 94700 nM
For compound 3 the middle estimate is 4.2-fold (0.63 log units) above the measured one; the whole stated range lies above it.
By their numbers in this assay, from the lowest: compound 3; then compound 2; then compound 1.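

In this assay, among the compounds shown here, the hydroxymethyl on this saturated ring carbon gives the first single change that can be read, and swapping it for hydrogen is not neutral: it brings a 4.0-fold lower number from compound 2 to compound 3 (0.60 log units; beyond the scatter) and so shows that less compound is tolerated without this group. For the compounds shown here, neither of the earlier compounds could show this, as they differ in more than one place. Nothing at hand explains the step. Whether the carbon or the oxygen of the hydroxymethyl matters stays open, since the compounds shown hold neither a methyl nor a carboxylic acid at this place.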